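Swapping ethyl for methoxycarbonyl on compound 2

This account rests on a few compounds, and the source may have more. Where it says the series, first, only, none or still open, it means among the compounds named here.

- Compound 1 `COC(=O)c1c[nH]c2cc(OCCOc3ccccc3)c(OC)cc2c1=O`: > 20000 nM (a limit of the assay)
- Compound 2 `CCCCc1cc2c(=O)c(CC)c[nH]c2cc1OCCOc1ccccc1`: 360 nM

Among the compounds with values here, in an ADME assay on J774 cells (Mus musculus) for cytotoxicity (a lower number here means that less compound is needed, a higher number that more compound is needed for the effect), compound 2 gives 360 nM, the only exact number so far. Compound 1 shows > 20000 nM, which is a limit and not a number. Compound 3 `CCCCc1cc2c(=O)c(C(=O)OC)c[nH]c2cc1OCCOc1ccccc1` has methoxycarbonyl in place of ethyl on an aromatic carbon. Compound 1 also carries methoxycarbonyl and shows > 20000 nM, so a higher number, beyond the usual scatter, is expected here, although compound 1 differs elsewhere too. The expected change is an 8.3-fold higher number from compound 2 to compound 3 (0.92 log units; beyond the scatter). For compound 3 the estimated value is 3000 nM, with an expected range from 700 nM to 15000 nM.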

Compound 3, half-maximal effective concentration: > 20000 nM
Compound 3 was reported as a limit (the forecaster's own chance of this, stated with the estimate: 15%); at least 6.6-fold (0.82 log units) between middle value and limit.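

In this assay, methoxycarbonyl in place of ethyl on this aromatic carbon gives an at least 55-fold higher number from compound 2 to compound 3 (1.74 log units; beyond the scatter), with the rest of the compound unchanged. Within the data shown here, compound 1 also carries methoxycarbonyl but differs elsewhere, so only this pair ties the change to this position. The step from compound 1 to compound 3 cannot be read: the limit of > 20000 nM in this assay, at which 2 of the 3 values shown sit.

From the compounds shown here alone, the value of compound 3 is a limit, so the full size of the step stays open. Also open, going by these compounds, is where a carboxylic acid or a longer chain such as propyl on this carbon would fall.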